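Chloro for Methoxy: Expecting Compound 4's Growth Inhibition

The source may report more compounds than this note shows. Statements on the series, on what has been measured and on what is new or still open speak of the compounds shown alone.

Three measured compounds share one core. In a functional assay on UACC-62 cells (Homo sapiens) for inhibition, read by sulforhodamine B assay, with a stated time of 48 h (on this read-out lower numbers stand for stronger inhibition of growth and higher numbers for weaker inhibition of growth), compound 1 `COc1ccc(-c2ccc(-c3ccc(C(=N)N)cc3)s2)cc1` gives 1410 nM, the lowest of the three numbers shown, though compound 2 `N=C(N)c1ccc(-c2ccc(-c3cc(Cl)cc(Cl)c3)s2)cc1` at 1550 nM and compound 3 `COc1ccc(-c2ccc(-c3ccc(C(=N)N)c(F)c3)s2)cc1` at 1820 nM both lie within the scatter of it. Within the data shown here, the only single-point step seen, a 1.3-fold higher number from compound 1 to compound 3 (0.11 log units; within the scatter), stays inside that scatter. Compound 4 `N=C(N)c1ccc(-c2ccc(-c3ccc(Cl)cc3)s2)cc1` differs from compound 1 by chloro in place of methoxy on an aromatic carbon. Among the measured compounds shown here, no measured step makes this same exchange; compound 2, which carries chloro groups but no methoxy, merely shows a number close to that of compound 1. With every change so far flat, compound 4 is expected to give about 1500 nM in this assay, within 700 nM to 3200 nM, a step of a 1.1-fold higher number from compound 1 to compound 4 (0.03 log units; within the scatter).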

Compound 4, concentration for 50% growth inhibition: 178 nM
Compound 4: middle estimate off by 8.4-fold (0.93 log units), on the high side; the whole stated range lies above it.
By their numbers in this assay, from the lowest: compound 4; then compounds 1, 2 and 3 (each within the scatter of the next).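

In this assay, the swap of chloro for methoxy on this aromatic carbon, para to a large group, gives a 7.9-fold lower number from compound 1 to compound 4 (0.90 log units; beyond the scatter), the only step shown that lies beyond the scatter. Among these compounds, the number at this position can therefore change markedly with a single exchange, which the flat earlier comparisons did not reveal. Nothing measured here gives a reason for this step.

The compounds shown leave open whether other groups on this carbon, such as bromo, methyl or an amine, would give numbers like those of compound 4 or compound 1.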